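Two sulfonyl hydrazides at the limit, a third awaited

The compounds below may be only part of what the source reports. "The series", "measured", "known", "first", "only" and "open" are said of these compounds alone.

Compound 1 `CC(=O)Nc1ccc(S(=O)(=O)NNC(=O)c2cccnc2Nc2ccc(Cl)cc2)cc1`: > 100000 nM
Compound 2 `O=C(NNS(=O)(=O)c1ccc(F)cc1)c1cccnc1Nc1ccc(Cl)cc1Cl`: > 100000 nM

In a functional assay on NCI-H322 cells (Homo sapiens) for antiproliferative activity (on this read-out lower numbers stand for stronger inhibition of growth and higher numbers for weaker inhibition of growth), compound 1 gives only a limit, > 100000 nM. Compound 2 likewise gives only a limit in this assay, > 100000 nM. Compound 1 therefore stands where both measured values sit, as the limit of > 100000 nM in this assay, at which 2 of the 2 values shown sit, shows. Compound 3 `O=C(NNS(=O)(=O)c1ccc(Cl)cc1Cl)c1cccnc1Nc1ccc(Cl)cc1` differs from compound 1 by 2,4-dichlorophenyl in place of 4-acetamidophenyl on a sulfonyl sulfur. Within the data shown here, no measured pair shows this step, so the expectation rests on both measured compounds sitting at the limit. The step from compound 1 to compound 3 is expected to be a number no higher from compound 1 to compound 3 (the limit leaves the size open), none beyond the scatter. For compound 3 the estimate in this assay is 100000 nM, within 30000 nM to 300000 nM.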

Compound 3, concentration for total growth inhibition: 40700 nM
The estimate for compound 3 lay 2.5-fold (0.39 log units) above the measured number; low and high end bracket the measured number.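

In this assay, the group on the sulfonyl sulfur can change the outcome: 2,4-dichlorophenyl in place of 4-acetamidophenyl gives an at least 2.4-fold lower number from compound 1 to compound 3 (0.39 log units; beyond the scatter). Among these compounds, compound 3 supplies the first actual number here, while the other results are limits: the limit of > 100000 nM in this assay, at which 2 of the 3 values shown sit. In this single step, a hydrogen-bond donor and acceptor leave and chlorine enters, and the step cannot separate these changes.

On these data alone, compound 1 gives only a limit, > 100000 nM, so the full size of the step stays open. As far as these compounds go, how an amine or a carboxylic acid on the sulfonyl sulfur's phenyl ring would compare also stays open.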